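A few compounds are considered here, and "the series" means these few. Any claim that something is new, unique, unknown or untested is made for them only; others in the source may bear on it.

Compound 1 `O=C(Nc1cccc(-n2cc(-c3ccncc3)c(-c3cc(O)cc(Cl)c3)n2)c1)Nc1ccc(Cl)c(C(F)(F)F)c1`: in a functional assay on RPMI-8226 cells (Homo sapiens) for inhibition, read by sulforhodamine B assay, with a stated time of 48 h, tested at 100 uM (a lower number here means a stronger effect, a higher number a weaker effect of the compound at the concentration tested), compound 1 gives -30%.
Compound 2 `O=C(Nc1cccc(-n2cc(-c3ccncc3)c(-c3cc(O)cc(Cl)c3)n2)c1)Nc1ccc(Cl)c(Cl)c1`: in this assay compound 2 gives -27%.
Compound 3 `COc1cc(Cl)cc(-c2nn(-c3cccc(NC(=O)Nc4cc(C(F)(F)F)cc(C(F)(F)F)c4)c3)cc2-c2ccncc2)c1`: in this assay compound 3 gives -8%.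

Compound 3 stands highest of the three numbers in this assay, that is, it shows the weakest effect; compound 2 lies nearest, beyond the scatter below it, and compound 1 furthest, also beyond the scatter. Compound 4 `COc1cc(Cl)cc(-c2nn(-c3cccc(NC(=O)Nc4cccc(C(F)(F)F)c4)c3)cc2-c2ccncc2)c1` differs from compound 3 in one place: hydrogen in place of trifluoromethyl on an aromatic carbon. Among the compounds with values here, the one measured step that bears on this is a change at a trifluoromethyl of the same terminal ring, a number 3 percentage points higher from compound 1 to compound 2 (within the scatter), a step within the scatter. On that basis compound 4 is expected to move little, a number 2 percentage points higher from compound 3 to compound 4 (within the scatter), and the estimate for compound 4 in this assay is -6%, with a range of -28% to 14%.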

Compound 4, a percentage reported as activity, at one concentration (the size of the read-out at that concentration, not a potency): -43%
For compound 4 the middle estimate is 37 percentage points above the measured one; measured number outside the range, below it.
By their numbers in this assay, from the lowest: compound 4; then compounds 1 and 2 (each within the scatter of the next); then compound 3.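

Hydrogen in place of trifluoromethyl, at this place meta to a trifluoromethyl group, gives a number 35 percentage points lower from compound 3 to compound 4 (beyond the scatter) in this assay. The earlier change on this ring, chloro in place of trifluoromethyl, gave a number 3 percentage points higher from compound 1 to compound 2 (within the scatter) and so gave no sign that this ring could respond so strongly. Nothing measured here accounts for the size of the step. The compounds shown leave open how a methyl, an amine or a carboxylic acid at this place would compare with hydrogen and trifluoromethyl.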